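Phenoxy to Isopropoxy on a Pyridyl Ether Side Chain

A few compounds are considered here, and "the series" means these few. Any claim that something is new, unique, unknown or untested is made for them only; others in the source may bear on it.

Of the compounds shown here, two have so far been measured in an in vitro assay on SH-SY5Y cells for displacement of a labelled ligand from Neuronal acetylcholine receptor; alpha3/beta4 (Homo sapiens); on this read-out lower numbers stand for stronger inhibition and higher numbers for weaker inhibition. Compound 1 `C1=C(c2cnccn2)CC2CNCC1C2` gives 828 nM in this assay. Compound 2 `C1=C(c2cncc(Oc3ccccc3)c2)CC2CNCC1C2` gives 1.9 nM in this assay. Of the two numbers, compound 2 stands lowest, and its separation from compound 1 lies well beyond the scatter of repeated measurements of this kind.

Compound 3 `CC(C)Oc1cncc(C2=CC3CNCC(C2)C3)c1` has not yet been measured. Relative to compound 2 it differs in a single place: isopropyl in place of phenyl on an oxygen on an aromatic ring. Within the data shown here, no pair of measured compounds isolates this particular change, so its effect cannot be read directly from the numbers at hand; the expectation below rests on compound 2 alone and on the nature of the change. Because compound 2 gives 1.9 nM, the remaining room for a lower number is small, and the change is expected to move the number upward, that is toward weaker inhibition, by a step beyond the scatter. The expected step is a 7.9-fold higher number from compound 2 to compound 3 (0.90 log units; beyond the scatter). Compound 3 is accordingly estimated at 15 nM, with a range from 3 nM to 80 nM.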

Compound 3, inhibition constant: 4.8 nM
Compound 3: the middle estimate sits 3.1-fold (0.49 log units) above what was measured, and the stated range covers the measured number.
By their numbers in this assay, from the lowest: compound 2; then compound 3; then compound 1.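

Taking out phenyl and putting isopropyl on the oxygen on the aromatic ring gives a 2.5-fold higher number from compound 2 to compound 3 (0.40 log units; beyond the scatter) in this assay, a modest step, and compound 3 still gives 4.8 nM. This position therefore does not need an aromatic ring to keep a low number: isopropyl, with no ring and 3 heavy atoms, stands in for phenyl, with its six-membered aromatic ring and 6 heavy atoms, at a small but real cost. The compounds offer no evidence that would explain the size of this step.

This single pair leaves open how the number would respond to other groups on the same oxygen, such as methyl, cyclopentyl or benzyl, and so whether size, branching or the ring itself matters most. Among these compounds, it also leaves open whether the oxygen is needed at all, as an amine in its place would show, and whether the step from phenoxy to isopropoxy would keep its size on any core other than the one shared by compound 2 and compound 3.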